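Sulfonamide Variations Sitting at the Assay Limit

The source may report more compounds than this note shows. Statements on the series, on what has been measured and on what is new or still open speak of the compounds shown alone.

Compound 1, `O=S(=O)(Nc1ccc(-c2nc3ccccc3o2)cc1)c1ccccc1C(F)(F)F`, gives only a limit in an assay on isolated protein for inhibition of malate dehydrogenase, mitochondrial (Sus scrofa), with stated times of 45 min and 30 min; on this read-out lower numbers stand for stronger inhibition and higher numbers for weaker inhibition: > 63000 nM.
Compound 2, `Cc1ccccc1S(=O)(=O)Nc1ccc(-c2nc3ccccc3o2)cc1`, gives only a limit in this assay: > 63000 nM.
Compound 3, `COc1ccc(S(=O)(=O)Nc2ccc3oc(-c4ccccc4)nc3c2)cc1`, gives only a limit in this assay: > 63000 nM.

All three measured compounds share the same picture: compound 2 stands at the limit of this assay, and the other two values stand there as well, so that (the limit of > 63000 nM in this assay, at which 3 of the 3 values shown sit). Going by the values given here, the one step between two compounds that differ in a single place, a step that the two limits leave unreadable from compound 1 to compound 2, runs from one limit to another, and its size is therefore not readable. Among the compounds with values here, nothing measured so far shows a change in this assay that can be given a size or a direction.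

Compound 4, `O=S(=O)(Nc1ccc(-c2nc3ccccc3o2)cc1)c1cccc(F)c1`, differs from compound 2 in one place: 3-fluorophenyl in place of 2-methylphenyl on a sulfonyl sulfur. Within the data shown here, since the only related step carries no readable size, no step beyond the scatter can be expected in either direction, and the most likely outcome is that compound 4 is again reported as a limit. Compound 4 is therefore expected to show a step that the limit leaves unreadable from compound 2 to compound 4 from compound 2. Compound 4 is estimated at 90000 nM, with a range from 30000 nM to 300000 nM.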

Compound 4, half-maximal inhibitory concentration: > 63000 nM
Compound 4: no number, only a limit; the forecaster's own chance of this, stated with the estimate: 85%; the middle value does not contradict the limit.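

Compound 4 is reported only as a limit, just as compound 2 is, so the step between these two compounds cannot be read, because neither gives a number: the limit of > 63000 nM in this assay, at which 4 of the 4 values shown sit.

The compounds shown leave open whether any change to the sulfonamide groups or the shared core would give a measurable value in this assay.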